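Acetyl to methyl on the piperazine of compound 2

The source may hold more compounds than are shown below. What is called first, only, known or untested is meant among the compounds shown, and "the series" means these compounds.

Measured compounds:
compound 1, `COc1cccc(-c2ccc3c(NC(=O)c4ccc(N5CCN(C)CC5)c(F)c4)n[nH]c3c2)c1F`, > 1000 nM
compound 2, `COc1ccc(F)c(-c2ccc3c(NC(=O)c4ccc(N5CCN(C(C)=O)CC5)cc4)n[nH]c3c2)c1F`, 322 nM

In a functional assay on SNU-16 cells (Homo sapiens) for antiproliferative activity, read by CCK-8 assay, with a stated time of 72 h (on this read-out lower numbers stand for stronger inhibition and higher numbers for weaker inhibition), compound 1 gives > 1000 nM, which is a limit of the assay rather than a number, (the limit of > 1000 nM in this assay, at which 1 of the 2 values shown sits). Compound 2 gives the only number shown, 322 nM. Compound 3 is `COc1ccc(F)c(-c2ccc3c(NC(=O)c4ccc(N5CCN(C)CC5)cc4)n[nH]c3c2)c1F`; it differs from compound 2 by methyl in place of acetyl on an amine nitrogen in a ring. Within the data shown here, no measured pair isolates this change, so a step of a 1.2-fold higher number from compound 2 to compound 3 (0.09 log units; within the scatter) is expected, amounting to no more than the scatter in either direction. Compound 3 is therefore expected to give 400 nM, between 120 nM and 1500 nM.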

Compound 3, half-maximal inhibitory concentration: 35.6 nM
Estimate against measurement, compound 3: 11-fold (1.05 log units) above; the measured number lies below the stated range.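

In this assay the change from 4-acetylpiperazin-1-yl to 4-methylpiperazin-1-yl gives a 9.0-fold lower number from compound 2 to compound 3 (0.96 log units; beyond the scatter) and so shows that the group on this ring nitrogen affects the read-out. Among these compounds, this is the first comparison here in which only one place differs, and the step lies beyond the scatter. Nothing measured here accounts for it.

The compounds shown leave open whether the methyl itself matters or only the removal of the acetyl carbonyl. An ethyl, a hydrogen or a longer chain on this nitrogen could help separate the two readings.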